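A few compounds are considered here, and "the series" means these few. Any claim that something is new, unique, unknown or untested is made for them only; others in the source may bear on it.

Measured so far:
- Compound 1, `CCNC(=O)Cn1nc(N)c2c(C(F)(F)F)cc(-c3ccccc3)nc21`: 21300 nM in a functional assay on MCF7 cells (Homo sapiens) for cytotoxicity, read by MTT assay, with a stated time of 24 h; a lower number here means a stronger inhibitor, a higher number a weaker inhibitor
- Compound 2, `Nc1nn(CC(=O)NC2CC2)c2nc(-c3ccccc3)cc(C(F)(F)F)c12`: "not active" (no number reported) in this assay

Both compounds share one core and differ only in the amide at the end of the side chain. Compound 1 carries an ethylamide and gives a weak result of 21300 nM in this assay. Compound 2 carries a cyclopropylamide and is reported in this assay as "not active" (no number reported), so no number stands for it at all; it cannot be placed on the scale beside compound 1, only noted as giving no measurable inhibition within the tested range.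

Compound 3, `Nc1nn(CC(=O)N2CCOCC2)c2nc(-c3ccccc3)cc(C(F)(F)F)c12`, is derived from compound 2 by the change (morpholin-4-yl in place of cyclopropylamino on a carbonyl carbon). The ring on the amide becomes larger, a donor leaves and an acceptor enters. For the measured compounds named here, no step between two measured compounds is available here to guide the size of this change, so the expectation rests on the weak picture given by compound 1 and the absence of a number for compound 2: compound 3 is expected to remain weak, with a real chance that this assay again reports no number. As a point estimate, compound 3 is expected to give about 40000 nM, with a plausible range from 12000 nM to 150000 nM.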

Compound 3, half-maximal inhibitory concentration: 5900 nM
Compound 3: the middle estimate sits 6.8-fold (0.83 log units) above what was measured; measured number below the stated range.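

Morpholin-4-yl in place of ethylamino on a carbonyl carbon gives a 3.6-fold lower number from compound 1 to compound 3 (0.56 log units; beyond the scatter) in this assay, so the group at the end of the side chain can shift this result by more than the usual scatter, even with the shared core left unchanged. The morpholin-4-yl group of compound 3 brings no amide hydrogen, so that hydrogen is not required for a measurable result in this series; the step from compound 2 to compound 3 cannot be read, however, since compound 2 has no number to set against compound 3. Nothing measured alongside these results accounts for the difference between the amides.

The compounds shown leave open whether the oxygen of the morpholin-4-yl ring matters or whether a ring of that size is enough, a question that piperidin-1-yl, with carbon in place of that oxygen, could help to settle on the same carbonyl carbon. They also leave open whether a longer chain between the shared core and the carbonyl would keep, lose or improve the result seen for compound 3.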